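Swapping a Difluorophenyl for a Hydroxyphenyl Group

The source may report more compounds than this note shows. Statements on the series, on what has been measured and on what is new or still open speak of the compounds shown alone.

Compound 1 (`O=C1O/C(=C\Cn2cc(-c3cc(F)cc(F)c3)nn2)C(OCc2ccccc2)=C1OCc1ccccc1`) was tested in a functional assay on MCF7 cells (Homo sapiens) for antiproliferative activity, read by MTT assay, with a stated time of 72 h (on this read-out lower numbers stand for stronger inhibition and higher numbers for weaker inhibition), and in this read-out compound 1 gives only a limit, > 100000 nM. Among the numbers so far it stands at the limit of > 100000 nM in this assay, at which 1 of the 2 values shown sits. Compound 2 (`O=C1O[C@H]([C@@H](O)Cn2cc(C3CC3)nn2)C(OCc2ccccc2)=C1OCc1ccccc1`), built on a differently arranged version of the shared core, gives 25900 nM in this assay. Among the measured compounds shown here, no step between compound 1 and compound 2 is defined, so the two numbers show only that compound 2 returns a measured value where compound 1 does not. The unmeasured compound 3 (`O=C1O/C(=C\Cn2cc(-c3cccc(O)c3)nn2)C(OCc2ccccc2)=C1OCc1ccccc1`) differs from compound 1 by 3-hydroxyphenyl in place of 3,5-difluorophenyl on an aromatic carbon. Compound 3 is expected to improve only modestly, a step of an at least 1.4-fold lower number from compound 1 to compound 3 (0.15 log units; that floor lies within the scatter). Compound 3 is therefore estimated at 70000 nM, within 15000 nM to 300000 nM, with a fair chance that this assay again reports only a limit.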

Compound 3, half-maximal inhibitory concentration: 27800 nM
For compound 3 the middle estimate is 2.5-fold (0.40 log units) above the measured one, within the range that was stated.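

The position on the aromatic carbon of the five-membered aromatic ring with 3 nitrogen proves responsive to the group it carries: in this assay, 3-hydroxyphenyl in place of 3,5-difluorophenyl gives an at least 3.5-fold lower number from compound 1 to compound 3 (0.55 log units; beyond the scatter). Among the compounds shown here, this step lies beyond the scatter, and it is the first one that can be read at this position, with the rest of the structure unchanged. Compound 1 remains a limit, so the size of the step is only a floor: the limit of > 100000 nM in this assay, at which 1 of the 3 values shown sits.

The compounds shown leave open whether the step comes from gaining the hydroxyl group or from losing the two fluorines. They also leave open how a plain phenyl, a 3-methoxyphenyl or a 3-aminophenyl group would read at this position.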